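From methoxy to methylsulfanyl in a cytotoxic pair

The compounds below may be only part of what the source reports. "The series", "measured", "known", "first", "only" and "open" are said of these compounds alone.

Measured so far in a functional assay on HeLa cells (Homo sapiens) for cytotoxicity, read by sulforhodamine B assay; on this read-out higher numbers stand for weaker inhibition and lower numbers for stronger inhibition:
compound 1 `COc1ccc(N(C)c2nc(C)nc3ccccc23)cc1` gives 1.5 nM
compound 2 `COc1ccc2c(c1)CCCN2c1nc(C)nc2ccccc12` gives 1.2 nM

Compound 1 stands level with compound 2, the two values lying within the usual scatter of each other. The two differ at more than one place, so they offer no guide to the size of a single change. Compound 3 (`CSc1ccc(N(C)c2nc(C)nc3ccccc23)cc1`) has not yet been measured. It differs from compound 1 at one place (methylsulfanyl in place of methoxy on an aromatic carbon), with methylsulfanyl in place of methoxy on an aromatic carbon, para to a large group. The only anchor for this expectation is compound 1 at 1.5 nM in this assay on the shared scale. The estimated step is small and toward a higher number (a 2.7-fold higher number from compound 1 to compound 3 (0.43 log units; beyond the scatter)), and a result within the scatter would be no surprise. The estimate puts compound 3 at 4 nM with an expected range from 1.2 nM to 20 nM once it is measured.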

Compound 3, half-maximal inhibitory concentration: 1.1 nM
Estimate against measurement, compound 3: 3.6-fold (0.56 log units) above; measured number outside the range, below it.
By their numbers in this assay, from the lowest: compounds 3, 2 and 1 (each within the scatter of the next).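

In this assay, putting methylsulfanyl in place of methoxy on an aromatic carbon, para to a large group, amounts to a 1.4-fold lower number from compound 1 to compound 3 (0.13 log units; within the scatter), so the two groups read level at this position. Going by these compounds alone, this is the first measure of a single change, which the earlier pair, differing at more than one place, could not give. Nothing available here bears on why the oxygen and sulfur groups read alike.

The compounds shown leave open how this position would respond to groups of another kind or size, such as an amine, a carboxylic acid or a longer chain. As far as these compounds go, it also remains open whether the same change would read level in compound 2, which also carries a methoxy group.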